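The source may hold more compounds than are shown below. What is called first, only, known or untested is meant among the compounds shown, and "the series" means these compounds.

Of the compounds shown here, three sharing one core have been tested in a functional assay on MCF7 cells (Homo sapiens) for cytotoxicity, read by MTT assay, with a stated time of 96 h; a higher number here means a weaker inhibitor, a lower number a stronger inhibitor. Compound 1 `Cc1cc2c(c(=O)o1)C(c1ccco1)C(C#N)=C(N)O2`, which carries furan-2-yl on a saturated ring carbon, gives 27000 nM. Compound 2 `Cc1cc2c(c(=O)o1)C(c1ccc(C)s1)C(C#N)=C(N)O2`, with 5-methylthiophen-2-yl there, gives 22000 nM. Compound 3 `Cc1ccc(C2C(C#N)=C(N)Oc3cc(C)oc(=O)c32)cc1`, with 4-methylphenyl, gives 54000 nM. Compound 3 lies together with compound 1 at the high-number end of this narrow range, and the only clear gap is a 2.5-fold higher number from compound 2 to compound 3 (0.39 log units; beyond the scatter).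

Compound 4 `COc1ccc(C2C(C#N)=C(N)Oc3cc(C)oc(=O)c32)cc1` has methoxy in place of methyl on an aromatic carbon, a change counted as methoxy in place of methyl on an aromatic carbon. For the measured compounds named here, no measured step tests this exchange directly. The nearest evidence comes from swaps of the whole group on the saturated ring carbon, such as a 1.2-fold lower number from compound 1 to compound 2 (0.09 log units; within the scatter) and a 2.0-fold higher number from compound 1 to compound 3 (0.30 log units; within the scatter), and these are small. On that limited evidence, no step beyond the scatter is expected in this assay. Compound 4 is estimated at 42000 nM, with an expected range from 18000 nM to 95000 nM. The expected move is a 1.3-fold lower number from compound 3 to compound 4 (0.11 log units; within the scatter).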

Compound 4, half-maximal inhibitory concentration: 57000 nM
Compound 4: middle estimate off by 1.4-fold (0.13 log units), on the low side, and the stated range covers the measured number.
By their numbers in this assay, from the lowest: compounds 2, 1, 3 and 4 (each within the scatter of the next, the first and the last beyond it).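

Up to this point, every comparison in this assay swapped the whole group on the saturated ring carbon. For the compounds shown here, compound 4 is the first to keep the six-membered aromatic ring and alter only the small group on it, para to a large group. Methoxy, which brings an oxygen and a hydrogen-bond acceptor, in place of methyl gives (a 1.1-fold higher number from compound 3 to compound 4 (0.02 log units; within the scatter)), so the two compounds cannot be told apart in this assay, and nothing available bears on why they read alike.

The compounds shown carry only methyl and methoxy at this place, so the effect of an amine, a carboxylic acid or a longer chain such as butoxy there remains open. Also open, on these data alone, is whether methoxy in place of methyl would read the same on the 5-methylthiophen-2-yl group of compound 2.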